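The compounds below may be only part of what the source reports. "The series", "measured", "known", "first", "only" and "open" are said of these compounds alone.

Compound 1 `O=C(C1CC1)N1CCc2nc(C#Cc3ccccc3)sc2C1` gives 290 nM in an assay on HEK293 cells for negative allosteric modulation of metabotropic glutamate receptor 5 (Homo sapiens), read by FLIPR, with a stated time of 1 h; on this read-out lower numbers stand for stronger inhibition and higher numbers for weaker inhibition. Compound 3 `O=C(C1CCC1)N1CCc2nc(C#Cc3ccccc3)sc2C1` gives 370 nM. Compound 2 `CC1CC1C(=O)N1CCc2nc(C#Cc3ccccc3)sc2C1` gives only a limit of the assay, > 10000 nM.

Compound 1 and compound 3 share a core and differ by cyclobutyl in place of cyclopropyl on a carbonyl carbon, a change that gives a 1.3-fold higher number from compound 1 to compound 3 (0.11 log units; within the scatter). Adding a methyl to the cyclopropyl of compound 1, (methyl in place of hydrogen on a saturated ring carbon), gives an at least 34-fold higher number from compound 1 to compound 2 (1.53 log units; beyond the scatter), where compound 2 sits at the limit of > 10000 nM in this assay, at which 1 of the 3 values shown sits.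

Compound 4 `CC1CC(C(=O)N2CCc3nc(C#Cc4ccccc4)sc3C2)C1` is not yet measured. It differs from compound 3 by methyl in place of hydrogen on a saturated ring carbon. This is the same kind of change as from compound 1 to compound 2, but not the same: there the methyl stands "on a saturated ring carbon of a three-membered non-aromatic ring of carbon only; next to the ring atom that bears a large group", here "on a saturated ring carbon of a four-membered non-aromatic ring of carbon only; two ring bonds from the ring atom that bears a large group".

For compound 4 the step expected in this assay is a 5.4-fold higher number from compound 3 to compound 4 (0.73 log units; beyond the scatter), set beside an at least 34-fold higher number from compound 1 to compound 2 (1.53 log units; beyond the scatter); this rests on that one earlier example of a methyl added to the small ring, which gave a large loss, softened here, the ring and the position of the methyl not being the same. Compound 4 is therefore estimated at 2000 nM, expected to lie between 400 nM and 10000 nM.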

Compound 4, half-maximal inhibitory concentration: > 10000 nM
Compound 4 gave a limit, no number; the forecaster's own chance of this, stated with the estimate: 30%; middle value at least 5.0-fold (0.69 log units) away from the limit.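

In this assay compound 4 gives > 10000 nM, which is a limit of the assay and not a number, and it now shares that limit with compound 2: the limit of > 10000 nM in this assay, at which 2 of the 4 values shown sit.

Putting a methyl on the cyclobutyl ring gives an at least 27-fold higher number from compound 3 to compound 4 (1.43 log units; beyond the scatter), and going from cyclopropyl all the way to 3-methylcyclobutyl gives an at least 34-fold higher number from compound 1 to compound 4 (1.53 log units; beyond the scatter), while the step between the two methyl compounds cannot be read, as both ends are limits. So on the two cores shown, a methyl added to the small ring on the carbonyl carbon goes with a large loss each time, but this does not give the true size of either loss, and two cases make no rule for other cores: the same change on two cores in this assay, an at least 34-fold higher number (1.53 log units; beyond the scatter) from compound 1 to compound 2 and an at least 27-fold higher number (1.43 log units; beyond the scatter) from compound 3 to compound 4; the limit leaves it open whether they differ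

The compounds shown leave open whether any group on these rings is accepted, for example a fluorine or a hydroxyl in place of the same hydrogen. They also leave open whether a larger unsubstituted ring, such as cyclopentyl on the carbonyl carbon, would stay close to compound 1 and compound 3.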